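A few compounds are considered here, and "the series" means these few. Any claim that something is new, unique, unknown or untested is made for them only; others in the source may bear on it.

Compound 1 `CCCC(=O)NC(c1ccc(Cl)cc1)c1cc(Cl)c2cccnc2c1O` — 100 nM
Compound 2 `O=C(NC(c1ccc(Cl)cc1Cl)c1ccc2cccnc2c1O)C1CCCC1` — 150 nM

In a functional assay on Daoy cells (Homo sapiens) for antiproliferative activity, read by trypan blue exclusion and crystal violet staining, with a stated time of 72 h (a higher number here means a weaker inhibitor, a lower number a stronger inhibitor), compound 1 gives 100 nM. Compound 2 gives 150 nM in this assay. On the two numbers shown, compound 1 holds the lower one, but the gap to compound 2 lies within the scatter of repeated measurements, so the two compounds cannot be told apart on this evidence, and no step between measured compounds has been worked out for them.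

Compound 3 `CCCC(=O)NC(c1ccc(C(C)C)cc1)c1cc(Cl)c2cccnc2c1O` has not yet been measured. It differs from compound 1 in one place: isopropyl in place of chloro on an aromatic carbon. Among the measured compounds shown here, no measured pair shows what this kind of exchange does in this assay, so there is nothing to lean on beyond the two values above and the change itself. A step of modest size is expected, with no clear direction that can be justified, so the expected step from compound 1 to compound 3 is a 1.5-fold higher number from compound 1 to compound 3 (0.18 log units; within the scatter), which is not beyond the scatter. Compound 3 is therefore estimated at 150 nM in this assay, with a range from 50 nM to 500 nM.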

Compound 3, half-maximal inhibitory concentration: 90 nM
For compound 3 the middle estimate is 1.7-fold (0.22 log units) above the measured one; the measured number falls inside the stated range.
By their numbers in this assay, from the lowest: compounds 3, 1 and 2 (each within the scatter of the next).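

In this assay, among the compounds shown here, isopropyl in place of chloro on the aromatic carbon para to a large group gives a 1.1-fold lower number from compound 1 to compound 3 (0.05 log units; within the scatter) and so provides the only measured step at this position. The 4-chlorophenyl and 4-isopropylphenyl versions of the shared core therefore cannot be told apart, and replacing a single chlorine with three carbon atoms at this position produces no difference that this measurement can resolve. No other measurement is available to explain this result.

Only chloro and isopropyl are shown at this position, so it remains open whether an amine, a carboxylic acid, a methoxy group or a plain hydrogen on the same aromatic carbon would also read like compound 1 and compound 3. As far as these compounds go, it is equally open whether the exchange of chloro for isopropyl would give a similar step with a longer chain on the amide carbonyl, or whether a larger group such as tert-butyl or phenyl at this position would still leave the number within the scatter.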